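The source may report more compounds than this note shows. Statements on the series, on what has been measured and on what is new or still open speak of the compounds shown alone.

Measured so far in an assay for inhibition of high affinity nerve growth factor receptor (Homo sapiens), read by HTRF, with a stated time of 30 min, in the presence of a further agent that is not named here; on this read-out lower numbers stand for stronger inhibition and higher numbers for weaker inhibition: compound 1, `Cc1cc(Nc2nc(NCc3ccc(F)cc3)nc3ccccc23)n[nH]1`, gives 20 nM; compound 2, `Cc1cc(Nc2nc(NCc3c(F)cccc3F)nc3ccccc23)n[nH]1`, gives 160 nM.

Compound 2 stands at the higher of the two numbers, and only compound 1 is close to it. Among the measured compounds shown here, the single step that joins them, an 8.0-fold higher number from compound 1 to compound 2 (0.90 log units; beyond the scatter), is the one measured step that bears on the change considered here. Compound 3, `Cc1cc(Nc2nc(NCc3ccc(F)c(F)c3)nc3ccccc23)n[nH]1`, differs from compound 2 by 3,4-difluorophenyl in place of 2,6-difluorophenyl on a saturated chain carbon bound to a nitrogen on an aromatic ring. For the measured compounds named here, no compound with a 3,4-difluorophenyl has been measured, so the step from compound 2 is judged only from the fact that 3,4-difluorophenyl, like the 4-fluorophenyl of compound 1, is not 2,6-difluorophenyl. The expectation is therefore that compound 3 moves back toward compound 1, a lower number beyond the scatter, with the estimated step of a 4.0-fold lower number from compound 2 to compound 3 (0.60 log units; beyond the scatter). Compound 3 is estimated at 40 nM, within a range of 12 nM to 130 nM.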

Compound 3, half-maximal inhibitory concentration: 74 nM
For compound 3 the middle estimate is 1.9-fold (0.27 log units) below the measured one; the range from low to high includes it.
By their numbers in this assay, from the lowest: compound 1; then compound 3; then compound 2.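

In this assay, the 3,4-difluorophenyl in place of the 2,6-difluorophenyl gives a 2.2-fold lower number from compound 2 to compound 3 (0.33 log units; beyond the scatter), so with the same atoms, the arrangement of the two fluorines at this place alone is enough to shift the number. Fluoro in place of hydrogen on the ring of compound 1 gives a 3.7-fold higher number from compound 1 to compound 3 (0.57 log units; beyond the scatter), so the return toward compound 1 is only partial and compound 1 still has the lowest number of the three. No measurement at hand accounts for the size of either step.

Going by these compounds, it remains open whether any fluoro is needed here, which a plain phenyl on the same chain carbon would address. Also open, on these data alone, is how a 4-chlorophenyl, a 4-methoxyphenyl or a longer chain between the ring and the nitrogen would compare with the 4-fluorophenyl of compound 1.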